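The source may hold more compounds than are shown below. What is called first, only, known or untested is meant among the compounds shown, and "the series" means these compounds.

Compound 1 `CC1(C)Cc2c(OCc3ccccc3)ccc(C(=O)/C=C/c3ccccc3)c2O1`, compound 2 `CC1(C)Cc2c(ccc(C(=O)/C=C/c3ccc(Cl)cc3Cl)c2OCc2ccccc2)O1` and compound 3 `CC1(C)Cc2c(ccc(C(=O)/C=C/c3ccccc3)c2OCc2ccccc2)O1` share one core and differ only in the aryl group carried on the double-bonded chain. In a functional assay on NCI-H460 cells (Homo sapiens) for antiproliferative activity, read by MTT assay, with a stated time of 48 h (a higher number here means a weaker inhibitor, a lower number a stronger inhibitor), compound 1 gives > 100000 nM, which is a limit of the assay. In this assay compound 2 gives > 100000 nM, again a limit. In this assay compound 3 gives > 100000 nM, also a limit. The step that the two limits leave unreadable from compound 2 to compound 3 is therefore unreadable in size. Compound 4 `CC1(C)Cc2c(ccc(C(=O)/C=C/c3ccc(Cl)cc3)c2OCc2ccccc2)O1` remains unmeasured and differs from compound 3 by chloro in place of hydrogen on an aromatic carbon. No readable measured step bears on this change; what is known is the limit of > 100000 nM in this assay, at which 3 of the 3 values shown sit. Compound 4 is expected to give 150000 nM, within 50000 nM to 500000 nM, most probably again as a limit. The step that the limit leaves unreadable from compound 3 to compound 4 is thus estimated as none beyond the scatter.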

Compound 4, half-maximal inhibitory concentration: > 100000 nM
Compound 4: only a limit was reported; the forecaster's own chance of this, stated with the estimate: 85%; the middle value is on the limit's open side.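

No step to compound 4 can be read from compound 2 or compound 3, all values being limits: the limit of > 100000 nM in this assay, at which 4 of the 4 values shown sit.

The compounds shown leave open whether any aryl group on the double-bonded chain gives a measurable value in this assay.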